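Benzyl Substitution on the Sulfamide of Compound 1

The compounds below may be only part of what the source reports. "The series", "measured", "known", "first", "only" and "open" are said of these compounds alone.

Compound 1 `NS(=O)(=O)N1CCC(C(=O)/C(=N/O)Nc2ccc(F)c(Br)c2)CC1` is characterised in an assay for inhibition of Indoleamine 2,3-dioxygenase 1 (Homo sapiens), with a stated time of 1 h (on this read-out higher numbers stand for weaker inhibition and lower numbers for stronger inhibition), where compound 1 gives 63 nM. It is the higher of the two numbers recorded so far; its nearest neighbour is compound 2 `O=C(/C(=N/O)Nc1ccc(F)c(Br)c1)C1CCN(C(=O)Nc2ccccc2)CC1`, which in this assay gives 40 nM, and the difference a 1.6-fold lower number from compound 1 to compound 2 (0.20 log units; within the scatter) lies within the scatter. Compound 3 `O=C(/C(=N/O)Nc1ccc(F)c(Br)c1)C1CCN(S(=O)(=O)NCc2ccccc2)CC1` is the next compound of the series. It is related to compound 1 by a single change, (benzyl in place of hydrogen on a sulfonamide nitrogen), which, cut one bond further out, reads as amino to benzylamino.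

Among the measured compounds shown here, only one measured step bears on this change, and only loosely: replacing the whole sulfamoyl group of compound 1 by phenylcarbamoyl, as in compound 2, moved the number by a 1.6-fold lower number from compound 1 to compound 2 (0.20 log units; within the scatter), a step within the scatter. Nothing measured shows what a benzyl group on the sulfonamide nitrogen itself does, so the expectation rests on the tolerance that step suggests. Compound 3 is therefore expected to sit close to compound 1, an estimated step of a 1.1-fold lower number from compound 1 to compound 3 (0.02 log units; within the scatter). The expected value of compound 3 in this assay is 60 nM, with a range from 25 nM to 150 nM.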

Compound 3, half-maximal inhibitory concentration: 24 nM
Compound 3: middle estimate off by 2.5-fold (0.40 log units), on the high side, outside the stated range (below it).
By their numbers in this assay, from the lowest: compounds 3, 2 and 1 (each within the scatter of the next, the first and the last beyond it).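

The benzyl group on the sulfonamide nitrogen gives a 2.6-fold lower number from compound 1 to compound 3 (0.42 log units; beyond the scatter) in this assay, and this is the only step shown here that lies beyond the scatter. The earlier step, a 1.6-fold lower number from compound 1 to compound 2 (0.20 log units; within the scatter), exchanged the whole sulfamoyl group and so said nothing about this nitrogen itself; the new step shows that the nitrogen, whose other neighbour is the sulfonyl sulfur, can carry a benzyl group in place of hydrogen and that the number then falls modestly rather than staying level. Nothing available explains why this change lowers the number.

The compounds shown leave open whether the step belongs to the aromatic ring or simply to the added carbon, a question that a methyl group or a cyclohexylmethyl group on the same nitrogen would address. They also leave open how far this position extends, for example whether a longer chain such as phenethyl, or a benzyl group bearing a carboxylic acid or an amine on its ring, would lower the number further or raise it again.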